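Amidoxime to O-ethyl amidoxime: solubility outlook in the indole series

The source may report more compounds than this note shows. Statements on the series, on what has been measured and on what is new or still open speak of the compounds shown alone.

Measured so far:
- compound 1 `N=C(N)c1ccc2[nH]c(-c3cccc(-c4cc(F)ccc4O)c3O)cc2c1`: 83000 nM
- compound 2 `N/C(=N/O)c1ccc2[nH]c(-c3cccc(-c4ccccc4O)c3O)cc2c1`: 380000 nM

In a physicochemical assay for solubility, in phosphate buffer, at pH 7.4 (on this read-out lower numbers stand for lower solubility and higher numbers for higher solubility), compound 2 gives 380000 nM, the higher of the two numbers; compound 1 gives 83000 nM, and the gap between them is beyond the usual scatter. For the measured compounds named here, compound 2 therefore stands as the more soluble of the two measured members.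

Compound 3 `CCONC(=N)c1ccc2[nH]c(-c3cccc(-c4ccccc4O)c3O)cc2c1` is the next point. It differs from compound 2 in one place: a group of 6 heavy atoms (3 carbon, 2 nitrogen, 1 oxygen; no ring) in place of a group of 4 heavy atoms (1 carbon, 2 nitrogen, 1 oxygen; no ring), on an aromatic carbon. The change adds carbon to the chain on the amidine-type group while keeping the count of hydrogen-bond donors and acceptors. Going by the values given here, no measured pair covers this kind of change, so its effect on this assay has to be estimated rather than read off. A modest downward step is expected, the step from compound 2 to compound 3 being about a 3.2-fold lower number from compound 2 to compound 3 (0.50 log units; beyond the scatter). For compound 3 the expected value is 120000 nM, with a range from 40000 nM to 380000 nM.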

Compound 3, solubility: 43000 nM
Estimate against measurement, compound 3: 2.8-fold (0.45 log units) above; low and high end bracket the measured number.
By their numbers in this assay, from the lowest: compounds 3 and 1 (each within the scatter of the next); then compound 2.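

In this assay this aromatic carbon proves sensitive to the group it carries: the group of 6 heavy atoms in place of the group of 4 heavy atoms gives an 8.8-fold lower number from compound 2 to compound 3 (0.95 log units; beyond the scatter). For the compounds shown here, this is the first step read at this position, and the shift beyond the scatter comes with equal counts of hydrogen-bond donors and acceptors and no net charge on either group, so those counts alone do not track the read-out in this pair. Nothing at hand accounts for the size of the step.

Going by these compounds, whether a methyl or a propyl chain in place of the ethyl chain of compound 3 would extend or reverse the step remains open. So does the reading for an amine or a carboxylic acid on this aromatic carbon.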